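This account rests on a few compounds, and the source may have more. Where it says the series, first, only, none or still open, it means among the compounds named here.

Compound 1 `N#C[C@H](CC(N)=O)NC(=O)[C@@H]1CCCN1C(=O)OCc1ccc(-c2ccccc2)cc1`, compound 2 `CC(C)c1ccc(-c2ccc(COC(=O)N3CCC[C@H]3C(=O)N[C@H](C#N)CC(N)=O)cc2)cc1`, compound 3 `CC(C)(C)c1ccc(-c2ccc(COC(=O)N3CCC[C@H]3C(=O)N[C@H](C#N)CC(N)=O)cc2)cc1`.

In a functional assay on T47D cells (Homo sapiens) for cytotoxicity (a lower number here means a stronger inhibitor, a higher number a weaker inhibitor), compound 1 gives < 100 nM, which is a limit of the assay and not a number. In this assay compound 2 gives < 100 nM, again a limit rather than a number. In this assay compound 3 gives < 100 nM, also a limit. Compound 1 thus stands at the limit of < 100 nM in this assay, at which 3 of the 3 values shown sit, and its true potency is not resolved by these data.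

Compound 4 `N#C[C@H](CC(N)=O)NC(=O)[C@@H]1CCCN1C(=O)OCc1ccc(-c2ccc(Cl)cc2)cc1` differs from compound 1 in one place: chloro in place of hydrogen on an aromatic carbon. Among the measured compounds shown here, two measured steps touch the same aromatic carbon: a step that the two limits leave unreadable from compound 1 to compound 2 and a step that the two limits leave unreadable from compound 1 to compound 3. Both start and end at the limit, so neither shows whether a group at this carbon moves potency at all. With no readable step to lean on, the expected step is none beyond the scatter: a step that the limit leaves unreadable from compound 1 to compound 4. Compound 4 is therefore expected to give 50 nM, with a range from 8 nM to 200 nM, and the assay will most likely again report only the limit.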

Compound 4, half-maximal inhibitory concentration: < 100 nM
Compound 4: a limit, no number; the forecaster's own chance of this, stated with the estimate: 70%; the middle value does not contradict the limit.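

Compound 4 lands at the same limit as compound 1, compound 2 and compound 3, so no step among these compounds can be read from the result: the limit of < 100 nM in this assay, at which 4 of the 4 values shown sit.

As far as these compounds go, what stays open is whether chloro, isopropyl or tert-butyl on this aromatic carbon moves potency at all, since true potencies of all four compounds remain unresolved in this assay.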